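Trimming a Trifluoromethyl from a Bis-Aryl Urea

The compounds below may be only part of what the source reports. "The series", "measured", "known", "first", "only" and "open" are said of these compounds alone.

Among the measured compounds shown here, compound 1 `O=C(Nc1cccc(-n2cc(-c3ccncc3)c(-c3ccc(Cl)c(O)c3)n2)c1)Nc1cc(C(F)(F)F)cc(C(F)(F)F)c1` is one of three compounds measured in a functional assay on SW-620 cells (Homo sapiens) for inhibition, read by sulforhodamine B assay, with a stated time of 48 h; on this read-out lower numbers stand for stronger inhibition of growth and higher numbers for weaker inhibition of growth. There compound 1 gives 1300 nM, the highest of the three numbers. Compound 2 `COc1cc(-c2nn(-c3cccc(NC(=O)Nc4ccc(Cl)c(C(F)(F)F)c4)c3)cc2-c2ccncc2)ccc1Cl` gives 1290 nM, which lies within the scatter of the number for compound 1. For the measured compounds named here, compound 3 `COc1cc(-c2nn(-c3cccc(NC(=O)c4ccccc4)c3)cc2-c2ccncc2)ccc1Cl` gives 551 nM, and the only single-point step among the measured compounds is a 2.3-fold lower number from compound 2 to compound 3 (0.37 log units; beyond the scatter), a change at the carbonyl carbon. Compound 4 `O=C(Nc1cccc(-n2cc(-c3ccncc3)c(-c3ccc(Cl)c(O)c3)n2)c1)Nc1cccc(C(F)(F)F)c1` differs from compound 1 by hydrogen in place of trifluoromethyl on an aromatic carbon. Going by the values given here, no measured step touches this position, so the step at the carbonyl carbon offers no direct guide. It is therefore expected that a 1.2-fold higher number from compound 1 to compound 4 (0.06 log units; within the scatter), a change not clearly beyond the scatter. Compound 4 is estimated at 1500 nM, within a range from 600 nM to 4000 nM.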

Compound 4, concentration for 50% growth inhibition: 3830 nM
The estimate for compound 4 lay 2.6-fold (0.41 log units) below the measured number, within the range that was stated.
By their numbers in this assay, from the lowest: compound 3; then compounds 2 and 1 (each within the scatter of the next); then compound 4.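

Hydrogen in place of trifluoromethyl on this aromatic carbon gives, in this assay, a 2.9-fold higher number from compound 1 to compound 4 (0.47 log units; beyond the scatter), so this position on the urea's aryl ring responds to the change, and the second trifluoromethyl goes with stronger inhibition of growth in this pair. Among the compounds shown here, no earlier step touched this position; the only one lay at the carbonyl carbon. Nothing measured here explains the difference.

Going by these compounds, what an amine or a carboxylic acid on this carbon would give remains open. So does whether the same change would carry over to the methoxy compound 2.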